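The source may report more compounds than this note shows. Statements on the series, on what has been measured and on what is new or still open speak of the compounds shown alone.

Measured so far in a functional assay, read by WST assay; a lower number here means a stronger inhibitor, a higher number a weaker inhibitor:
- compound 1 `CC(=O)Oc1ccc(/C=C/C(=O)O[C@@H]2C=C[C@@]3(C[C@H]2OC(=O)/C=C/c2ccc(OC(C)=O)c(OC(C)=O)c2)OC(C)(C)OC3=O)cc1OC(C)=O` gives 6.3 ug/mL
- compound 2 `O=C(/C=C/c1ccc(O)c(O)c1)O[C@@H]1C[C@](O)(C(=O)O)C=C[C@H]1O` gives 0.5 ug/mL
- compound 3 `CC[C@H]1OC(=O)[C@]2(C[C@@H](O)[C@H](O)[C@H](OC(=O)/C=C/c3ccc(O)c(O)c3)C2)O1` gives 1.1 ug/mL

Compound 3 sits in the middle of these three numbers, with compound 2 lower and compound 1 higher. Both gaps lie beyond the usual scatter.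

The next entry, compound 4 `CC[C@@H]1OC(=O)[C@]2(C[C@@H](O)[C@H](O)[C@H](OC(=O)/C=C/c3ccc(O)c(O)c3)C2)O1`, has not been measured. Against compound 3 it shows the two compounds have the same atoms and bonds and differ only in configuration as drawn: 1 of 6 stereo elements differ; a stereocentre at a saturated ring carbon is drawn R in compound 3 and S in compound 4 and nothing else changes. The stereocentre concerned is at a saturated ring carbon, drawn R in compound 3 and S in compound 4.

Among the measured compounds shown here, no measured pair in this small set differs in one place, so the data give no direct guide to the effect of this change. With no other difference between the two structures, no step beyond the scatter is expected in this assay and no firm direction can be assigned. The estimated step is a 1.1-fold higher number from compound 3 to compound 4 (0.04 log units; within the scatter) and it is expected to be small. The expected value for compound 4 is 1.2 ug/mL with an estimated range from 0.5 ug/mL to 2.8 ug/mL in this measurement.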

Compound 4, half-maximal inhibitory concentration: 1 ug/mL
For compound 4 the middle estimate is 1.2-fold (0.08 log units) above the measured one; the range from low to high includes it.
By their numbers in this assay, from the lowest: compounds 2, 4 and 3 (each within the scatter of the next, the first and the last beyond it); then compound 1.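

In this assay, changing the drawn configuration at this saturated ring carbon from R to S gives a 1.1-fold lower number from compound 3 to compound 4 (0.04 log units; within the scatter). Among the compounds shown here, this is the first pair that differs in one place, and it gives the first direct reading of a single change: the assay does not separate the two drawn configurations at this stereocentre. The reading can be tied to this stereocentre alone: the fact that compounds 3 and 4 differ only in the configuration as drawn

Going by these compounds, it remains open whether the remaining stereo elements are equally silent in this assay, as the pair speaks to only one of them. Also open, on these data alone, is how the number would respond to a longer chain or an amine at this saturated ring carbon, as the pair varies only the configuration there.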